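The compounds below may be only part of what the source reports. "The series", "measured", "known", "first", "only" and "open" are said of these compounds alone.

Three compounds share one core, a benzene ring carrying an imidazoline-bearing ether and an aromatic group on the neighbouring carbon, and differ only in that aromatic group. In a functional assay for activation of Alpha-1A adrenergic receptor (Homo sapiens), read by calcium flux (on this read-out lower numbers stand for an effect already at smaller amounts and higher numbers for an effect only at larger amounts of compound), compound 3 `c1coc(-c2ccccc2OCC2=NCCN2)c1` gives 1.26 nM, the lowest of the two numbers recorded. Compound 2 `Cc1cccc(-c2ccccc2OCC2=NCCN2)n1` gives 126 nM in this assay, a value that lies far beyond the usual scatter above that of compound 3. Compound 1 `Cc1ccnc(-c2ccccc2OCC2=NCCN2)c1` is reported in this assay only as a limit, < 100000 nM, and not as a number (the limit of < 100000 nM in this assay, at which 1 of the 3 values shown sits).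

Compound 4 `c1ccc(-c2ccns2)c(OCC2=NCCN2)c1` has not yet been measured in this assay. It departs from compound 3 by one change: 1,2-thiazol-5-yl in place of furan-2-yl on an aromatic carbon. For the measured compounds named here, no measured pair in this set isolates such a swap, so the direction of the step can only be guessed from the retained five-membered aromatic ring. The expectation for this step is a 2.4-fold higher number from compound 3 to compound 4 (0.38 log units; beyond the scatter), a change that may stay within the scatter or reach a modest loss. Compound 4 is therefore expected to give about 3 nM in this assay, most likely between 0.6 nM and 20 nM.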

Compound 4, half-maximal effective concentration: 5.01 nM
For compound 4 the middle estimate is 1.7-fold (0.22 log units) below the measured one; measured number inside the range.
By their numbers in this assay, from the lowest: compound 3; then compound 4; then compound 2.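

For the compounds shown here, compound 3 and compound 4 are the first pair here to isolate a swap at this position, and exchanging furan-2-yl for 1,2-thiazol-5-yl brings a 4.0-fold higher number from compound 3 to compound 4 (0.60 log units; beyond the scatter). The position therefore accepts a second five-membered aromatic ring with 2 hetero atoms at only a modest cost in this assay, and the number for compound 4 remains far lower than that of compound 2, 126 nM. No measurement shown here accounts for the size of this step.

The compounds shown leave open whether the sulfur or the added nitrogen drives the step, as the two enter together and neither is varied alone. They also leave open how this position would respond to a non-aromatic group, such as an amine or a carboxylic acid.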